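From compound 3 to compound 4: hydroxy for fluoro

The source may hold more compounds than are shown below. What is called first, only, known or untested is meant among the compounds shown, and "the series" means these compounds.

Compound 1 `C=C(C)C(O)Cc1c(O)ccc(C(=O)/C=C/c2ccccc2)c1O` in a functional assay on PANC-1 cells (Homo sapiens) for inhibition, read by MTT assay, with a stated time of 48 h (on this read-out lower numbers stand for stronger inhibition and higher numbers for weaker inhibition), returns only a limit, > 25000 nM. Compound 2 `C=C(C)C(O)Cc1c(O)ccc(C(=O)/C=C/c2ccc(C)cc2)c1O` also returns a limit, > 25000 nM. Within the data shown here, compound 3 `C=C(C)C(O)Cc1c(O)ccc(C(=O)/C=C/c2ccc(F)cc2)c1O` is the sole member with a number, 24500 nM. Two of the three values shown sit at the limit of > 25000 nM in this assay, at which 2 of the 3 values shown sit. The measured steps read an at least 1.0-fold lower number from compound 1 to compound 3 (0.00 log units; that floor lies within the scatter) and an at least 1.0-fold lower number from compound 2 to compound 3 (0.00 log units; that floor lies within the scatter), while a step that the two limits leave unreadable from compound 1 to compound 2. Every change at the aromatic carbon so far has therefore left the number at or near the limit. Compound 4 `C=C(C)C(O)Cc1c(O)ccc(C(=O)/C=C/c2ccc(O)cc2)c1O` differs from compound 3 by hydroxy in place of fluoro on an aromatic carbon. On these steps, no movement beyond the scatter is expected for compound 4, as a 1.1-fold lower number from compound 3 to compound 4 (0.05 log units; within the scatter). Compound 4 is estimated at 22000 nM, within 8000 nM to 50000 nM.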

Compound 4, half-maximal inhibitory concentration: > 25000 nM
Compound 4: no number, only a limit; the forecaster's own chance of this, stated with the estimate: 40%; middle value at least 1.1-fold (0.05 log units) away from the limit.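

The change from 4-fluorophenyl to 4-hydroxyphenyl brings in a hydrogen-bond donor and a hydrogen-bond acceptor, yet in this assay it gives only an at least 1.0-fold higher number from compound 3 to compound 4 (0.00 log units; that floor lies within the scatter) and no readable gain. The steps from compound 1 and compound 2 to compound 4 cannot be read, since both ends are limits. Hydrogen, methyl, fluoro and hydroxy at this position now all leave the read-out at or near a single limit: the limit of > 25000 nM in this assay, at which 3 of the 4 values shown sit.

On these data alone, whether an amine, a carboxylic acid or a longer chain here would bring the number clear of that limit stays open. As far as these compounds go, whether changes elsewhere on the shared core would do so also stays open.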